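This account rests on a few compounds, and the source may have more. Where it says the series, first, only, none or still open, it means among the compounds named here.

Working notes on the series around the shared core of compound 1 `C=C(C)C(=O)c1ccc(OCc2nc(C)no2)cc1C`.

In an assay on HL-60 cells for inhibition of glutathione S-transferase P (Homo sapiens) (a lower number here means a stronger inhibitor, a higher number a weaker inhibitor), compound 1 gives 5000 nM. Compound 2 `C=C(C)C(=O)c1ccc(OCc2nc(-c3ccccc3)no2)cc1C` carries a phenyl where compound 1 carries a methyl, and in this assay compound 2 gives 1970 nM; the change is a 2.5-fold lower number from compound 1 to compound 2 (0.40 log units; beyond the scatter). Compound 3 `C=C(C)C(=O)c1ccc(OCc2nc(C)no2)cc1Cl` carries a chloro on the benzene ring in place of the methyl of compound 1, and in this assay compound 3 gives 2100 nM, a change of a 2.4-fold lower number from compound 1 to compound 3 (0.38 log units; beyond the scatter). Among the three numbers compound 3 stands second highest; its value and that of compound 2 lie within the scatter of each other, and only compound 1 stands apart from it.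

Compound 4 `C=C(C)C(=O)c1ccc(OCc2nc(-c3ccccc3)no2)cc1Cl` is not yet measured. It differs from compound 3 in one place: phenyl in place of methyl on an aromatic carbon. Going by the values given here, the only measured step of the same kind is the one from compound 1 to compound 2, which was a 2.5-fold lower number from compound 1 to compound 2 (0.40 log units; beyond the scatter), made on the methyl-bearing analogue rather than the chloro-bearing one. Nothing measured speaks against the same change acting alike on compound 3, so a modest drop in the number is expected, about a 2.5-fold lower number from compound 3 to compound 4 (0.39 log units; beyond the scatter). On that basis compound 4 is estimated at 850 nM in this assay, with a range from 400 nM to 1800 nM.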

Compound 4, half-maximal inhibitory concentration: 600 nM
Estimate against measurement, compound 4: 1.4-fold (0.15 log units) above; measured number inside the range.
By their numbers in this assay, from the lowest: compound 4; then compounds 2 and 3 (each within the scatter of the next); then compound 1.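

In this assay, phenyl in place of methyl on the carbon between the two ring nitrogen atoms also lowers the number on the chloro-bearing core (a 3.5-fold lower number from compound 3 to compound 4 (0.54 log units; beyond the scatter)), so this change at this position now holds on two cores rather than one, with a size that carries over: the same change on two cores in this assay, a 2.5-fold lower number (0.40 log units; beyond the scatter) from compound 1 to compound 2 and a 3.5-fold lower number (0.54 log units; beyond the scatter) from compound 3 to compound 4, 1.4-fold (0.14 log units) apart, within the scatter of two such steps.

Chloro in place of methyl on the benzene ring likewise carries over from the methyl-bearing core to the phenyl-bearing one (a 3.3-fold lower number from compound 2 to compound 4 (0.52 log units; beyond the scatter)): the same change on two cores in this assay, a 2.4-fold lower number (0.38 log units; beyond the scatter) from compound 1 to compound 3 and a 3.3-fold lower number (0.52 log units; beyond the scatter) from compound 2 to compound 4, 1.4-fold (0.14 log units) apart, within the scatter of two such steps.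

Across these four compounds, neither change shows any dependence on the other and no compound goes against this, so the two changes together give compound 4 a lower number than either compound 2 or compound 3, each of which carries only one of them.

As far as these compounds go, whether the lower number at the ring carbon needs an aromatic ring or only more carbon remains open, and an ethyl group, a longer chain or a cyclohexyl ring there would separate the two. Also open, from the compounds shown here alone, is how far the trend on the benzene ring extends, for example to bromo, methoxy or an amine in place of the chloro.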